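This account rests on a few compounds, and the source may have more. Where it says the series, first, only, none or still open, it means among the compounds named here.

Measured so far in a functional assay on L1210 cells (Mus musculus) for inhibition; a higher number here means a weaker inhibitor, a lower number a stronger inhibitor:

compound 1 `COC(=O)Nc1nc2cc(C(=O)OC(C)C)ccc2[nH]1` — 700 nM
compound 2 `COC(=O)Nc1nc2cc(C(=O)OCC3CC3)ccc2[nH]1` — 6900 nM
compound 3 `COC(=O)Nc1nc2cc(C(=O)NCC(C)(C)C)ccc2[nH]1` — 8600 nM

Compound 1 has the lowest number of the three in this assay; compound 2 lies nearest to it, compound 3 furthest, and both gaps run beyond the scatter, so compound 1 is the strongest inhibitor of the set so far.

Compound 4 `COC(=O)Nc1nc2cc(C(=O)OCCC(C)C)ccc2[nH]1` is not yet measured. It differs from compound 1 in one place: isopentyl in place of isopropyl on an oxygen next to a carbonyl group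

Within the data shown here, two measured steps bear on this. Enlarging the ester group from compound 1 gave a 9.9-fold higher number from compound 1 to compound 2 (0.99 log units; beyond the scatter). Replacing the isopropoxy group by a larger amide gave a 12-fold higher number from compound 1 to compound 3 (1.09 log units; beyond the scatter). Between compound 2 and compound 3 the step was a 1.2-fold higher number from compound 2 to compound 3 (0.10 log units; within the scatter), so the two larger groups end up close to each other. Among the measured compounds shown here, every enlargement at this position so far has weakened inhibition by about the same amount; no case of the opposite exists in the set. The isopentyl group of compound 4 is again larger than isopropyl, so a weakening of comparable size is expected in this assay, though an acyclic chain may fall somewhat short of the cyclopropylmethyl case.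

Compound 4 is therefore estimated at 4000 nM, within 1200 nM to 12000 nM, which is expected to read as a 5.7-fold higher number from compound 1 to compound 4 (0.76 log units; beyond the scatter).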

Compound 4, half-maximal inhibitory concentration: 10000 nM
Estimate against measurement, compound 4: 2.5-fold (0.40 log units) below; measured number inside the range.
By their numbers in this assay, from the lowest: compound 1; then compounds 2, 3 and 4 (each within the scatter of the next).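

In this assay, isopentyl in place of isopropyl on an oxygen next to a carbonyl group gives a 14-fold higher number from compound 1 to compound 4 (1.15 log units; beyond the scatter), which shows that the loss seen with cyclopropylmethyl does not require a ring in the ester group. Among these compounds, compound 4 cannot be told apart from the other two weaker compounds, with a 1.4-fold higher number from compound 2 to compound 4 (0.16 log units; within the scatter) and a 1.2-fold higher number from compound 3 to compound 4 (0.07 log units; within the scatter), so neither the cyclopropyl ring nor the change from ester oxygen to amide nitrogen separates these three, and among the four compounds only compound 1 stands apart, with no compound going against that split. Nothing available gives a cause for this split.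

The compounds shown leave open how narrow the requirement at this position is: whether the step up in the number already appears with sec-butyl or isobutyl on the same oxygen, and whether ethyl, methyl or the free carboxylic acid would match or beat compound 1. They also leave open whether a longer chain such as n-octyl stays level with compound 4 or moves away from it.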